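The source may report more compounds than this note shows. Statements on the series, on what has been measured and on what is new or still open speak of the compounds shown alone.

In a functional assay on NCI-H1299 cells (Homo sapiens) for antiproliferative activity, read by fluorescence and resazurin assay, with a stated time of 48 h (on this read-out lower numbers stand for stronger inhibition and higher numbers for weaker inhibition), compound 1 `COc1ccccc1Cn1cc(-c2ccc(O)cc2)c(-c2ccc(O)cc2)c1` gives 23100 nM and compound 2 `COc1ccc(-c2cn(Cc3ccc(O)cc3)cc2-c2ccc(OC)c(OC)c2)cc1OC` gives 30600 nM. Compound 3 `COc1cc(-c2cn(Cc3ccc(O)cc3)cc2-c2cc(OC)c(OC)c(OC)c2)cc(OC)c1OC` reads > 100000 nM, which is a limit of the assay and not a number. Compound 4 `COc1cc(-c2cn(Cc3ccc(O)c(O)c3)cc2-c2cc(OC)c(OC)c(OC)c2)cc(OC)c1OC` differs from compound 3 in one place, a 4-hydroxybenzyl having become a 3,4-dihydroxybenzyl: hydroxy in place of hydrogen on an aromatic carbon. Going by the values given here, no measured pair of compounds shows this change, so the expectation is loose. Among the compounds with values here, a modest move towards stronger inhibition in this assay is expected, since compound 1, the one with hydroxy groups on both aryl arms, gives 23100 nM. The expected step is an at least 2.5-fold lower number from compound 3 to compound 4 (0.39 log units; beyond the scatter). For compound 4 the estimated value is 40000 nM, with an expected range of 10000 nM to 130000 nM.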

Compound 4, half-maximal inhibitory concentration: 29200 nM
Compound 4: the middle estimate sits 1.4-fold (0.14 log units) above what was measured; the range from low to high includes it.
By their numbers in this assay, from the lowest: compounds 1, 4 and 2 (each within the scatter of the next). At a limit, above all of these: compound 3.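

Replacing the 4-hydroxybenzyl with a 3,4-dihydroxybenzyl gives an at least 3.4-fold lower number from compound 3 to compound 4 (0.53 log units; beyond the scatter) in this assay. Going by these compounds alone, this is the first sign that this place on the benzyl group affects the read-out, with nothing else altered. Compound 3 reads as a limit and not a number, so the full size of the step stays unknown: the limit of > 100000 nM in this assay, at which 1 of the 4 values shown sits.

On these data alone, it remains open whether an amine or a fluorine at this same place would give a like step, or whether only hydroxy does. As far as these compounds go, whether the added hydroxy would act alike with the aryl arms of compound 1 or compound 2 also remains open.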